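Working notes: the step from compound 2 to compound 3

The source may hold more compounds than are shown below. What is called first, only, known or untested is meant among the compounds shown, and "the series" means these compounds.

Measured so far in a functional assay on HUVEC cells (Homo sapiens) for antiproliferative activity, read by MTT assay, with a stated time of 24 h; a higher number here means a weaker inhibitor, a lower number a stronger inhibitor
Compound 1 `COc1cc(OC)c(-c2coc3cc(OCc4ccccc4F)ccc3c2=O)cc1OC` gives 4300 nM
Compound 2 `COc1cc(OC)c(-c2coc3cc(OCc4ccccc4Cl)ccc3c2=O)cc1OC` gives > 10000 nM as a limit

The reading of compound 2 at > 10000 nM is a limit of the assay and not a number. Compound 3 `COc1cc(OC)c(-c2coc3cc(OCc4ccc(C(F)(F)F)cc4)ccc3c2=O)cc1OC` differs from it by 4-(trifluoromethyl)phenyl in place of 2-chlorophenyl on a saturated chain carbon bound to an oxygen on an aromatic ring with 4-(trifluoromethyl)phenyl in place of 2-chlorophenyl on a saturated chain carbon bound to an oxygen on an aromatic ring. Within the data shown here, the one measured step bearing on this is an at least 2.3-fold higher number from compound 1 to compound 2 (0.36 log units; beyond the scatter) with chloro in place of fluoro on an aromatic carbon. That step is modest, so a step of similar size towards a lower number is expected, and a reading at the limit remains possible. The expected move is an at least 1.4-fold lower number from compound 2 to compound 3 (0.15 log units; that floor lies within the scatter) in this assay as a rough guide. Compound 3 is estimated at 7000 nM with an expected range from 2000 nM to 20000 nM in this assay for now.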

Compound 3, half-maximal inhibitory concentration: > 10000 nM
Compound 3 gave a limit, no number; the forecaster's own chance of this, stated with the estimate: 40%; middle value at least 1.4-fold (0.15 log units) away from the limit.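

In this assay compound 3 gives > 10000 nM, a limit of the assay and not a number. With 4-(trifluoromethyl)phenyl in place of 2-fluorophenyl on the saturated chain carbon bound to an oxygen on an aromatic ring, the reading shows an at least 2.3-fold higher number from compound 1 to compound 3 (0.36 log units; beyond the scatter), so a second change at this position, besides chloro in place of fluoro, also moves away from compound 1. The step between compound 2 and compound 3 cannot be read, leaving 2-chlorophenyl and 4-(trifluoromethyl)phenyl unranked: the limit of > 10000 nM in this assay, at which 2 of the 3 values shown sit.

On these data alone, whether an amine or a carboxylic acid on the benzyl ring, or a longer chain in place of the benzyl carbon, would give a reading below this limit stays open.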